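The compounds below may be only part of what the source reports. "The series", "measured", "known", "first", "only" and "open" are said of these compounds alone.

Measured so far:
compound 1, `COc1ccc(-n2c(=O)n(Cc3cc4cc(Cl)ccc4n3CCCC#N)c3cnccc32)cc1OC`, in an ADME assay on HeLa cells (Homo sapiens) for cytotoxicity, read by ATP content, with a stated time of 3 days (a lower number here means that less compound is tolerated, a higher number that more compound is tolerated), gives > 50000 nM
compound 2, `CC(C)CCn1c(Cn2c(=O)n(C3CC3)c3ccncc32)nc2ncccc21`, in this assay gives > 100000 nM

Neither result is a number. For compound 1 the value > 50000 nM is a limit of this assay, as in the limit of > 50000 nM in this assay, at which 1 of the 2 values shown sits. For compound 2 the value > 100000 nM is likewise a limit, as in the limit of > 100000 nM in this assay, at which 1 of the 2 values shown sits. Compound 1 thus stands at one of the two limits seen, and the two results cannot be ordered against each other. Going by the values given here, no step between measured compounds is available in this assay.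

Compound 3, `N#CCCCn1c(Cn2c(=O)n(-c3ccc(C(=O)O)cc3)c3ccncc32)cc2cc(Cl)ccc21`, differs from compound 1 by 4-carboxyphenyl in place of 3,4-dimethoxyphenyl on an aromatic nitrogen. Among the compounds with values here, with no measured step for a change of this kind, no shift beyond the scatter is expected, and the estimated step that the limit leaves unreadable from compound 1 to compound 3 is set near zero. Compound 3 is expected at 80000 nM, within 30000 nM to 200000 nM, and most likely reported once more only as a limit in this assay.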

Compound 3, half-maximal cytotoxic concentration: > 50000 nM
Compound 3: a limit, no number (the forecaster's own chance of this, stated with the estimate: 80%); the middle value does not contradict the limit.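

No step can be read from compound 1 to compound 3 in this assay: both results are limits, not numbers. The compounds shown leave open whether 4-carboxyphenyl in place of 3,4-dimethoxyphenyl on an aromatic nitrogen changes the half-maximal cytotoxic concentration at all.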